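A Fluorinated Variant on a Shared Core

The compounds below may be only part of what the source reports. "The series", "measured", "known", "first", "only" and "open" are said of these compounds alone.

Compound 3 `COc1ccc(C2=NOC(COc3ccc(-c4nnnn4-c4cc(OC)c(OC)c(OC)c4)cc3N)C2)cc1N` gives 2080 nM in a functional assay on A549 cells (Homo sapiens) for cytotoxicity, read by MTT assay, with a stated time of 48 h (on this read-out lower numbers stand for stronger inhibition and higher numbers for weaker inhibition), the second highest of the three numbers, with both neighbours within the scatter: compound 1 `COc1ccc(-c2nnnn2-c2cc(OC)c(OC)c(OC)c2)cc1N` at 2630 nM and compound 2 `COc1cc(-n2nnnc2-c2ccc(OCC3CC(c4cccc(Cl)c4)=NO3)c(N)c2)cc(OC)c1OC` at 1340 nM. Compound 4 `COc1cc(-n2nnnc2-c2ccc(OCC3CC(c4ccccc4F)=NO3)c(N)c2)cc(OC)c1OC` differs from compound 3 in one place: 2-fluorophenyl in place of 3-amino-4-methoxyphenyl on a carbon with a double bond to nitrogen. Among the measured compounds shown here, one measured step bears on this change. Compound 2 also carries a halogen-bearing phenyl group at that same carbon, and there a 1.6-fold higher number from compound 2 to compound 3 (0.19 log units; within the scatter). Returning to a halogen-bearing phenyl group is therefore expected to move the number only slightly, a 1.3-fold lower number from compound 3 to compound 4 (0.11 log units; within the scatter), not beyond the scatter. Compound 4 is accordingly estimated at 1600 nM, within a range from 700 nM to 3500 nM.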

Compound 4, half-maximal inhibitory concentration: 1490 nM
Estimate against measurement, compound 4: 1.1-fold (0.03 log units) above; low and high end bracket the measured number.
By their numbers in this assay, from the lowest: compounds 2, 4, 3 and 1 (each within the scatter of the next).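

In this assay, 2-fluorophenyl in place of 3-amino-4-methoxyphenyl (a 1.4-fold lower number from compound 3 to compound 4 (0.14 log units; within the scatter)) and in place of 3-chlorophenyl (a 1.1-fold higher number from compound 2 to compound 4 (0.05 log units; within the scatter)) stays within the scatter, so three different substituted phenyl groups now sit at this carbon without a step beyond it. Adding the whole fluorinated side chain to the shared core (a 1.8-fold lower number from compound 1 to compound 4 (0.25 log units; within the scatter)) also stays within the scatter. No measurement here offers an explanation for these numbers. As far as these compounds go, it remains open whether a non-phenyl group at this carbon, such as a morpholine or a carboxylic acid, would move the number beyond the scatter.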